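Trading Fluoro for Hydrogen: What to Expect for Compound 4

A few compounds are considered here, and "the series" means these few. Any claim that something is new, unique, unknown or untested is made for them only; others in the source may bear on it.

Of the compounds shown here, three have so far been tested in a functional assay on the whole organism for inhibition, with Rattus norvegicus as the target, read by paw edema, at a dose of 50 mg/kg; on this read-out lower numbers stand for less inhibition and higher numbers for more inhibition at the one dose given (going by the name of the read-out). Compound 1 `O=c1oc2cccnc2n1CN1CCN(c2cccc(C(F)(F)F)c2)CC1` gives 25%, compound 2 `O=c1oc2cccnc2n1CCN1CCN(c2ccc(F)cc2)CC1` gives 16%, and compound 3 `O=c1oc2cccnc2n1CCCN1CCN(c2ccccc2)CC1` gives 16%. Compound 2 stands level with compound 3, the two together being the lowest of the three numbers, and its gap to compound 1 lies within the scatter of repeated measurements, so no order can be read from these results. Compound 4 `O=c1oc2cccnc2n1CCN1CCN(c2ccccc2)CC1` is the unmeasured partner of compound 2; the change is hydrogen in place of fluoro on an aromatic carbon. Fluoro leaves and a hydrogen atom enters. Within the data shown here, no measured pair shows this exact exchange, yet compound 3 also carries a phenyl and gives 16%. The expected step from compound 2 to compound 4 in this assay is no change at the digits printed from compound 2 to compound 4 (within the scatter), none beyond the scatter. Compound 4 is therefore estimated at 16%, with a range from 5% to 30%.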

Compound 4, a percentage reported as inhibition, in the whole organism at one dose (the size of the read-out at that dose, not a potency): 13%
Estimate against measurement, compound 4: 3 percentage points above; measured number inside the range.
By their numbers in this assay, from the lowest: compounds 4, 2, 3 and 1 (each within the scatter of the next, the first and the last beyond it).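

In this assay, hydrogen in place of fluoro on an aromatic carbon gives a number 3 percentage points lower from compound 2 to compound 4 (within the scatter). Among these compounds, this is the first pair differing in only one place, and it shows that this read-out does not separate 4-fluorophenyl from phenyl at this position. No measurement here offers an explanation for this result. Still open, going by these compounds, is whether another group on the same aromatic carbon, such as a methoxy group or a carboxylic acid, would shift the number beyond the scatter. A single dose also leaves potency unknown.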